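This account rests on a few compounds, and the source may have more. Where it says the series, first, only, none or still open, it means among the compounds named here.

Of the compounds shown here, three built on one shared core have been tested in a functional assay on KB cells (Homo sapiens) for antiproliferative activity, read by sulforhodamine B assay, with a stated time of 3 days; a lower number here means that less compound is needed, a higher number that more compound is needed for the effect. Compound 1 `CCC1=C(O)c2c(oc(-c3ccc(CC)cc3)cc2=O)C(CC)(CC)C1=O` gives 21.9 uM. Compound 2 `CCC1=C(O)c2c(oc(-c3ccc(C(C)C)cc3)cc2=O)C(CC)(CC)C1=O` gives 8.13 uM. Compound 3 `CCC1=C(O)c2c(oc(-c3ccc(CC(C)C)cc3)cc2=O)C(CC)(CC)C1=O` gives 29.3 uM, the highest of the three numbers; its gap to compound 1 lies within the scatter of repeated measurements, whereas a 3.6-fold higher number from compound 2 to compound 3 (0.56 log units; beyond the scatter). The remaining steps among the measured compounds are a 2.7-fold lower number from compound 1 to compound 2 (0.43 log units; beyond the scatter) and a 1.3-fold higher number from compound 1 to compound 3 (0.13 log units; within the scatter).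

Compound 4 `CCC1=C(O)c2c(oc(-c3ccc(Br)cc3)cc2=O)C(CC)(CC)C1=O` is the next compound, differing from compound 3 in a single place: bromo in place of isobutyl on an aromatic carbon. The measured steps all swap one alkyl group for another at that same position on the ring, so none of them directly tells what a bromo group does there. What they do show is the scale of movement this position has produced so far: from a step within the scatter up to a modest change in either direction. On that basis a step of modest size at most is expected for compound 4, with no firm direction; the estimate for compound 4 in this assay is 15 uM, within a range from 5 uM to 50 uM, which corresponds to an expected step of a 2.0-fold lower number from compound 3 to compound 4 (0.29 log units; within the scatter).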

Compound 4, concentration for half-maximal effect: > 48.1 uM
Compound 4 was reported as a limit; the forecaster's own chance of this, stated with the estimate: 5%; middle value at least 3.2-fold (0.50 log units) away from the limit.
By their numbers in this assay, from the lowest: compound 2; then compounds 1 and 3 (each within the scatter of the next). At a limit, above all of these: compound 4.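

In this assay compound 4 is reported as a limit and not as a number: the limit of > 48.1 uM in this assay, at which 1 of the 4 values shown sits. Among the compounds shown here, until now this position on the ring had only carried one alkyl group in place of another, and bromo is the first group of a different kind there, with an at least 5.9-fold higher number from compound 2 to compound 4 (0.77 log units; beyond the scatter) and an at least 2.1-fold higher number from compound 1 to compound 4 (0.34 log units; beyond the scatter), so swapping isopropyl or ethyl for bromo clearly raises the amount of compound needed. The comparison with the isobutyl compound is less firm, since an at least 1.6-fold higher number from compound 3 to compound 4 (0.21 log units; that floor lies within the scatter) has a floor that does not separate compound 4 from compound 3.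

With a single halogen at this position, the compounds shown cannot tell whether the rise belongs to bromo in particular or would appear with any group that is not an alkyl chain. Going by these compounds, how a chlorine, a methoxy group, an amine, a carboxylic acid or a longer chain would behave at this place on the ring stays open, and so does whether any group there could bring the number below that of compound 2.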